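The source may hold more compounds than are shown below. What is called first, only, known or untested is meant among the compounds shown, and "the series" means these compounds.

Measured so far:
compound 1 `CCCN(CCC)c1ccc(Nc2ncc(Cl)c(Oc3cccc(NC(=O)CC)c3)n2)cc1` — in an assay on isolated protein for inhibition of NUAK family SNF1-like kinase 2 (Homo sapiens), read by ADP-Glo, with a stated time of 60 min, tested at 10 uM, in the presence of a further agent that is not named here (a higher number here means more inhibition at the concentration tested (going by the name of the read-out), a lower number less inhibition), compound 1 gives "not active" (no number reported)
compound 2 `CCC(=O)Nc1cccc(Oc2nc(Nc3ccc(N(C)C)cc3OC)ncc2Cl)c1` — in this assay compound 2 gives 15%

Compound 1 has no single number in this assay; it is recorded only as inactive, so no position on a scale can be given for it. Compound 3 `CCC(=O)Nc1cccc(Oc2nc(Nc3ccc(N4CCN(C)CC4)cc3)ncc2Cl)c1` differs from compound 1 by 4-methylpiperazin-1-yl in place of dipropylamino on an aromatic carbon. Among the measured compounds shown here, no step between measured compounds is available to guide this change, and compound 2 shows that a related amine on the same ring gives only a small read-out. The account expects a step in this assay of modest size, if any, toward slightly more inhibition, but likely within the scatter. Compound 3 is estimated at 15%, between 0% and 40%.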

Compound 3, a percentage reported as inhibition, at one concentration (the size of the read-out at that concentration, not a potency): 82.6%
Compound 3: the middle estimate sits 67.6 percentage points below what was measured, and the stated range ends below it.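

Among the compounds shown here, compound 1 carries no number, so no step from it to compound 3 can be read. Nothing on hand explains the result of compound 3. The compounds shown leave open how much the 4-methylpiperazin-1-yl group itself contributes to inhibition.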